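Adding a butylcarbamoyl group to compound 1

A few compounds are considered here, and "the series" means these few. Any claim that something is new, unique, unknown or untested is made for them only; others in the source may bear on it.

Compound 1 `CC[C@@H]1C(=O)N(C)c2cnc(-n3ccc4ccccc43)nc2N1C1CCCC1` gives 17200 nM
Compound 2 `CC[C@@H]1C(=O)N(C)c2cnc(Nc3ccc(S(N)(=O)=O)cc3)nc2N1C1CCCC1` gives 394 nM

In a functional assay on MCF7 cells (Homo sapiens) for antiproliferative activity, read by CCK-8 assay, with a stated time of 72 h (a lower number here means a stronger inhibitor of growth, a higher number a weaker inhibitor of growth), compound 1 stands highest of the two measured compounds at 17200 nM, while compound 2 gives 394 nM, a lower number by a gap beyond the scatter. The account now turns to compound 3 `CCCCNC(=O)c1ccc2c(ccn2-c2ncc3c(n2)N(C2CCCC2)[C@H](CC)C(=O)N3C)c1`, which keeps the core of compound 1 but carries butylcarbamoyl in place of hydrogen on an aromatic carbon. That carbon belongs to a six-membered aromatic ring of carbon only, part of a fused or bridged system of two rings. Among the compounds with values here, no two measured compounds differ in one place, so the data offer no direct precedent for this change, and any forecast remains uncertain. A modest move towards a stronger inhibitor of growth is expected in this assay, although a result within the scatter would not be surprising. The estimated size of this move is a 2.2-fold lower number from compound 1 to compound 3 (0.33 log units; beyond the scatter) (a lower number expected). For compound 3 the estimated value is 8000 nM (expected range 2000 nM to 30000 nM).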

Compound 3, concentration for 50% growth inhibition: 634 nM
Compound 3: the middle estimate sits 13-fold (1.10 log units) above what was measured; measured number outside the range, below it.
By their numbers in this assay, from the lowest: compounds 2 and 3 (each within the scatter of the next); then compound 1.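

In this assay, within the data shown here, butylcarbamoyl in place of hydrogen on an aromatic carbon gives a 27-fold lower number from compound 1 to compound 3 (1.43 log units; beyond the scatter), the first reading of a single change on this core. It shows that this carbon of the six-membered aromatic ring of carbon only, meta to a fused ring and para to a fused ring, accepts a substituent of this size, and that the change goes with much stronger inhibition of growth, so the weak value of compound 1 is not fixed by its core alone. Nothing measured here bears on what lies behind the size of this step.

The compounds shown leave open which part of the butylcarbamoyl group goes with the step, since a single pair cannot separate the amide from the butyl chain; a carboxylic acid, a primary amide or a methylcarbamoyl group on the same carbon would draw that line. As far as these compounds go, it also remains open whether butylcarbamoyl would give a step of similar size on another carbon of the same ring, or whether a longer chain or a terminal amine on the amide nitrogen would move the number further.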